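Ester in place of lactam amide on the shared core

The source may report more compounds than this note shows. Statements on the series, on what has been measured and on what is new or still open speak of the compounds shown alone.

Measured compounds:
compound 1 `Nc1sc(-c2ccc(Cl)cc2)c(-c2ccc(Cl)cc2)c1C(=O)N1CCCCC1=O` gives 1820 nM
compound 2 `CC1CN(C(=O)c2c(N)sc(-c3ccc(Cl)cc3)c2-c2ccc(Cl)cc2)CCN1` gives 4930 nM
compound 3 `CCCCNC(=O)c1c(N)sc(-c2ccc(Cl)cc2)c1-c1ccc(Cl)cc1` gives 8170 nM

In a functional assay on A549 cells (Homo sapiens) for inhibition, read by sulforhodamine B assay, with a stated time of 72 h (a higher number here means a weaker inhibitor, a lower number a stronger inhibitor), compound 1 holds the lowest number of the three measured. The steps of a 2.7-fold higher number from compound 1 to compound 2 (0.43 log units; beyond the scatter) and a 4.5-fold higher number from compound 1 to compound 3 (0.65 log units; beyond the scatter) both run upward beyond the scatter, while a 1.7-fold higher number from compound 2 to compound 3 (0.22 log units; within the scatter) stays within it. Compound 4 `COC(=O)c1c(N)sc(-c2ccc(Cl)cc2)c1-c1ccc(Cl)cc1` differs from compound 1 by methoxy in place of 2-oxopiperidin-1-yl on a carbonyl carbon. Among the compounds with values here, both measured steps from compound 1 exchange the 2-oxopiperidin-1-yl group on the carbonyl carbon and both raise the number modestly; no methoxy analogue has been measured, so the ester has no direct precedent here. A modest rise in this assay is therefore expected for compound 4, a 2.5-fold higher number from compound 1 to compound 4 (0.39 log units; beyond the scatter). Compound 4 is estimated at 4500 nM, with a range from 1500 nM to 14000 nM.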

Compound 4, half-maximal inhibitory concentration: 5040 nM
Estimate against measurement, compound 4: 1.1-fold (0.05 log units) below; the measured number falls inside the stated range.
By their numbers in this assay, from the lowest: compound 1; then compounds 2, 4 and 3 (each within the scatter of the next).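

In this assay, methoxy on the carbonyl carbon also loses ground against 2-oxopiperidin-1-yl, with a 2.8-fold higher number from compound 1 to compound 4 (0.44 log units; beyond the scatter) beyond the scatter, so a ring-free group of this size does no better than the amides. Methoxy cannot be told apart from the other two replacements, with a 1.6-fold lower number from compound 3 to compound 4 (0.21 log units; within the scatter) and a 1.0-fold higher number from compound 2 to compound 4 (0.01 log units; within the scatter) both within the scatter. No measured evidence bears on what sets 2-oxopiperidin-1-yl apart. Open, from the compounds shown here alone, is whether a carboxylic acid or a primary amide at this carbonyl carbon falls with these three. Also open, going by these compounds, is whether a five-membered lactam matches compound 1.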